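Pyridyl nitrogen position on the benzylidene tetralone series

The compounds below may be only part of what the source reports. "The series", "measured", "known", "first", "only" and "open" are said of these compounds alone.

Measured so far in a functional assay on RAW264.7 cells (Mus musculus) for inhibition; a higher number here means a weaker inhibitor, a lower number a stronger inhibitor:
- compound 1, `O=C1/C(=C/c2ccccc2Br)CCc2c(O)cccc21`: 1240 nM
- compound 2, `O=C1/C(=C/c2ccccn2)CCc2c(O)cccc21`: 740 nM
- compound 3, `O=C1/C(=C/c2cccnc2)CCc2c(O)cccc21`: 2950 nM

Compound 3 gives the highest number of the three in this assay; compound 1 sits nearest to it and compound 2 furthest. Going by the values given here, the one step that walks the nitrogen around the ring, a 4.0-fold higher number from compound 2 to compound 3 (0.60 log units; beyond the scatter), shows that the pyridine nitrogen position moves the read-out by a modest amount beyond the scatter.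

Compound 4, `O=C1/C(=C/c2ccncc2)CCc2c(O)cccc21`, is not yet measured. It differs from compound 3 by pyridin-4-yl in place of pyridin-3-yl on a double-bonded chain carbon bound to a double-bonded ring carbon. Among the compounds with values here, no measured pair covers a move from pyridin-3-yl to pyridin-4-yl, so the only guide is the size of the one nitrogen shift seen, from compound 2 to compound 3, and that gives no direction for this second shift. A step of comparable size in either direction, or none beyond the scatter, is possible; the working expectation is a number near that of compound 3, with a wide range. Compound 4 is therefore estimated at 2500 nM, between 700 nM and 9000 nM, which corresponds to an expected step of a 1.2-fold lower number from compound 3 to compound 4 (0.07 log units; within the scatter).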

Compound 4, half-maximal inhibitory concentration: 4170 nM
Beside the measured number, compound 4's estimate is 1.7-fold (0.22 log units) below it; low and high end bracket the measured number.
By their numbers in this assay, from the lowest: compounds 2 and 1 (each within the scatter of the next); then compounds 3 and 4 (each within the scatter of the next).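

In this assay the shift from pyridin-3-yl to pyridin-4-yl gives a 1.4-fold higher number from compound 3 to compound 4 (0.15 log units; within the scatter) and so does not separate these two nitrogen placements. Pyridin-2-yl does stand apart from both, with a 5.6-fold higher number from compound 2 to compound 4 (0.75 log units; beyond the scatter) alongside a 4.0-fold higher number from compound 2 to compound 3 (0.60 log units; beyond the scatter) in the same direction, so across these three compounds the nitrogen position reads as pyridin-2-yl against the other two rather than as a graded walk around the ring. No measured information on these compounds accounts for that separation.

On these data alone, whether an amine or a carboxylic acid added to the pyridin-2-yl ring would keep, widen or erase this separation remains open. Also open, as far as these compounds go, is whether the same nitrogen pattern would hold with a methoxy group in place of the hydroxyl on the shared core.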